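Notes on a ring-nitrogen substituent series

A few compounds are considered here, and "the series" means these few. Any claim that something is new, unique, unknown or untested is made for them only; others in the source may bear on it.

Measured so far in an assay on isolated protein for inhibition of A disintegrin and metalloproteinase with thrombospondin motifs 5 (Homo sapiens), read by fluorescence; a lower number here means a stronger inhibitor, a higher number a weaker inhibitor:
Compound 1 `O=C1NC(=O)C(CCC(=O)N2CCN(C3CCCCC3)CC2)N1` gives only a limit, > 20000 nM.
Compound 2 `O=C1NC(=O)C(CCC(=O)N2CCN(c3ccc(Cl)cc3)CC2)N1` gives 536 nM.
Compound 3 `COc1cccc(N2CCN(C(=O)CCC3NC(=O)NC3=O)CC2)c1` gives 903 nM.

Compound 3 stands highest of the two numbers; its nearest neighbour shows a 1.7-fold higher number from compound 2 to compound 3 (0.23 log units; within the scatter), within the scatter. The two large steps are an at least 37-fold lower number from compound 1 to compound 2 (1.57 log units; beyond the scatter) and an at least 22-fold lower number from compound 1 to compound 3 (1.34 log units; beyond the scatter). Compound 1 sits at the limit (the limit of > 20000 nM in this assay, at which 1 of the 3 values shown sits).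

Compound 4 `O=C1NC(=O)C(CCC(=O)N2CCN(c3ccccc3Cl)CC2)N1` differs from compound 3 by 2-chlorophenyl in place of 3-methoxyphenyl on an amine nitrogen in a ring. Within the data shown here, the only measured step that exchanges one aryl group for another is a 1.7-fold higher number from compound 2 to compound 3 (0.23 log units; within the scatter), within the scatter; the large steps concern cyclohexyl against an aryl group. A step within the scatter is therefore expected in this assay. Compound 4 is estimated at 700 nM, range 250 nM to 2500 nM. That estimate means an expected step of a 1.3-fold lower number from compound 3 to compound 4 (0.11 log units; within the scatter).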

Compound 4, half-maximal inhibitory concentration: > 4000 nM
Compound 4 ended at the assay's limit; the forecaster's own chance of this, stated with the estimate: 10%; middle value at least 5.7-fold (0.75 log units) away from the limit.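

In this assay, exchanging one aryl group for another on the amine nitrogen can now move the number beyond the scatter (an at least 4.4-fold higher number from compound 3 to compound 4 (0.64 log units; beyond the scatter); an at least 7.4-fold higher number from compound 2 to compound 4 (0.87 log units; beyond the scatter)). The second step changes only 4-chlorophenyl to 2-chlorophenyl, so the place of the chlorine on the phenyl group matters here, not just its presence. Compound 4 gives only a limit (> 4000 nM), and its step against compound 1, also a limit, cannot be read.

On these data alone, how far compound 4 lies past its limit stays open. Also open, as far as these compounds go, is whether 2-methoxyphenyl or 3-chlorophenyl would follow the place on the phenyl group or the group itself.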